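From 4-fluorophenyl to 4-nitrophenyl: notes on compound 3

The source may report more compounds than this note shows. Statements on the series, on what has been measured and on what is new or still open speak of the compounds shown alone.

In a functional assay on HeLa cells (Homo sapiens) for inhibition, with a stated time of 72 h (on this read-out lower numbers stand for an effect already at smaller amounts and higher numbers for an effect only at larger amounts of compound), compound 2 (`COc1cc(CNCc2ccncc2)ccc1OCc1ccc(F)cc1`) gives 6400 nM and lies within the scatter of compound 1 (`COc1cc(CNCc2ccncc2)ccc1OCc1ccc(C)cc1`), which gives 5000 nM in the same read-out. Compound 3 (`COc1cc(CNCc2ccncc2)ccc1OCc1ccc([N+](=O)[O-])cc1`) carries nitro in place of fluoro on an aromatic carbon, para to a large group (nitro in place of fluoro on an aromatic carbon). Among the compounds with values here, the one measured step at this place (a 1.3-fold higher number from compound 1 to compound 2 (0.11 log units; within the scatter)) was fluoro in place of methyl and stayed within the scatter. Within the data shown here, with compound 2 reached by that step (a 1.3-fold higher number from compound 1 to compound 2 (0.11 log units; within the scatter)) as the only guide, no change beyond the scatter is expected in this assay for compound 3, though nitro is untested here. The expected step (a 1.2-fold lower number from compound 2 to compound 3 (0.07 log units; within the scatter)) is an estimate of no real change. Compound 3 is estimated at 5500 nM with an expected range from 2000 nM to 15000 nM in this series.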

Compound 3, half-maximal effective concentration: 440 nM
Compound 3: middle estimate off by 13-fold (1.10 log units), on the high side; measured number below the stated range.
By their numbers in this assay, from the lowest: compound 3; then compounds 1 and 2 (each within the scatter of the next).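

The aromatic carbon para to a large group is not indifferent to what it carries: in this assay, nitro gives a 15-fold lower number from compound 2 to compound 3 (1.16 log units; beyond the scatter) and an 11-fold lower number from compound 1 to compound 3 (1.06 log units; beyond the scatter), whereas fluoro and methyl stayed within the scatter, with a 1.3-fold higher number from compound 1 to compound 2 (0.11 log units; within the scatter). Of the three groups shown, only nitro moves the number beyond the scatter at this place. Nothing available bears on the reason for this shift.

Going by these compounds, whether the shift is specific to nitro remains open. A nitrile, an amine or a carboxylic acid at the same place would test this.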